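A Smaller Ring Group at the Aromatic Nitrogen

The compounds below may be only part of what the source reports. "The series", "measured", "known", "first", "only" and "open" are said of these compounds alone.

Compound 2 `CNC(=O)Nc1ccc(-c2nc(N3CC4CCC(C3)O4)c3cnn(C4CCC5(CC4)OCCCO5)c3n2)cc1` is the starting point. In an in vitro ADME assay on microsomes (Homo sapiens) for metabolic stability (on this read-out higher numbers stand for a longer-lived compound and lower numbers for a shorter-lived compound), compound 2 reached only a limit of the assay, > 0.5 h. Compound 1 `CNC(=O)Nc1ccc(-c2nc(N3CC4CCC(C3)O4)c3cnn(C(C)C)c3n2)cc1` gave 0.2 h in this assay, and the step of an at least 2.5-fold higher number from compound 1 to compound 2 (0.39 log units; beyond the scatter) is the only measured one that bears on the change at hand. Compound 3 `CNC(=O)Nc1ccc(-c2nc(N3CC4CCC(C3)O4)c3cnn([C@H]4CC[C@@H](O)CC4)c3n2)cc1` differs from compound 2 as follows: a group of 7 heavy atoms (6 carbon, 1 oxygen; one six-membered non-aromatic ring of carbon only) in place of a group of 11 heavy atoms (9 carbon, 2 oxygen; one six-membered non-aromatic ring of carbon only, one six-membered non-aromatic ring with 2 hetero atoms), on an aromatic nitrogen. Since the ring group entering in compound 3 is smaller than the one it replaces yet larger than the group of compound 1, compound 3 is expected to fall between them, with an estimated half-life of 0.4 h (range 0.15 h to 1 h), a step of an at least 1.2-fold lower number from compound 2 to compound 3 (0.09 log units; that floor lies within the scatter).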

Compound 3, half-life: > 0.5 h
Compound 3: only a limit was reported; the forecaster's own chance of this, stated with the estimate: 35%; middle value at least 1.2-fold (0.09 log units) away from the limit.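

In this assay the smaller 4-hydroxycyclohexyl group on the aromatic nitrogen also beats isopropyl, with an at least 2.5-fold higher number from compound 1 to compound 3 (0.39 log units; beyond the scatter), so the full ring group of compound 2 is not needed for a step beyond the scatter. Compound 2 and compound 3 both stand at a limit of the assay, so the step between them cannot be read: the limit of > 0.5 h in this assay, at which 2 of the 3 values shown sit.

Going by these compounds, what remains open is how far compound 3 lies past its limit. On these data alone, it also remains open whether a plain cyclohexyl group would do the same, or how an amine in place of the hydroxy group would read.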